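Triazole dithiocarbamates against prostate cancer cells: a closed series

This account rests on a few compounds, and the source may have more. Where it says the series, first, only, none or still open, it means among the compounds named here.

Compound 1 `O=C(OCc1ccccc1)N1CCN(C(=S)SCc2cn(Cc3ccc(Cl)cc3)nn2)CC1` was tested in a functional assay on PC-3 cells (Homo sapiens) for inhibition, read by MTT assay, with a stated time of 72 h; on this read-out lower numbers stand for stronger inhibition and higher numbers for weaker inhibition. In this assay compound 1 gives > 128000 nM, which is a limit of the assay and not a number. Compound 2 `Cc1ccc(Cn2cc(CSC(=S)N3CCN(C(=O)OCc4ccccc4)CC3)nn2)cc1` differs from compound 1 by methyl in place of chloro on an aromatic carbon. In this assay compound 2 gives > 128000 nM, again a limit. The step is a step that the two limits leave unreadable from compound 1 to compound 2, because the limit of > 128000 nM in this assay, at which 3 of the 3 values shown sit, holds both values. The core of compound 3 `S=C(SCc1cn(Cc2ccc(Cl)cc2)nn1)N1CCNCC1` differs from that of compound 1 by hydrogen in place of benzyloxycarbonyl on an amine nitrogen in a ring; that step is a step that the two limits leave unreadable from compound 1 to compound 3. In this assay compound 3 gives > 128000 nM, a limit. Compound 4 `Cc1ccc(Cn2cc(CSC(=S)N3CCNCC3)nn2)cc1` differs from compound 3 by methyl in place of chloro on an aromatic carbon, the same change as that between compound 1 and compound 2. The expected step is a step that the limit leaves unreadable from compound 3 to compound 4, resting on compound 1 and compound 2 both sitting at the limit of > 128000 nM in this assay, at which 3 of the 3 values shown sit. Compound 4 is therefore expected to give 200000 nM, between 100000 nM and 600000 nM, most probably reported only as a limit.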

Compound 4, half-maximal inhibitory concentration: 19800 nM
The estimate for compound 4 lay 10-fold (1.00 log units) above the measured number; measured number outside the range, below it.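

In this assay, methyl in place of chloro, on the core with hydrogen on the ring nitrogen, gives an at least 6.4-fold lower number from compound 3 to compound 4 (0.81 log units; beyond the scatter), and hydrogen in place of benzyloxycarbonyl, with the methyl kept, gives an at least 6.4-fold lower number from compound 2 to compound 4 (0.81 log units; beyond the scatter). For the compounds shown here, both steps start from a limit of the assay, so their true size is not known, and compound 4 is the only one of the four compounds with a measured number. Whether methyl in place of chloro does anything on the benzyloxycarbonyl core cannot be read, so the change is not shown to carry from one core to the other, because compound 1 and compound 2 both sit at a limit: the limit of > 128000 nM in this assay, at which 3 of the 4 values shown sit.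

The compounds shown leave open whether methyl is special at this place, or whether a methoxy group, a fluoro group or an ethyl group would serve as well. They also leave open how an acetyl group or a methyl group on the ring nitrogen would compare with hydrogen there.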